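A few compounds are considered here, and "the series" means these few. Any claim that something is new, unique, unknown or untested is made for them only; others in the source may bear on it.

In a functional assay on HL-60 cells (Homo sapiens) for cytotoxicity, read by ELISA, with a stated time of 2 days (a higher number here means a weaker inhibitor, a lower number a stronger inhibitor), three compounds that differ at a single place on a shared core have been measured. Compound 1 `Oc1cccc(-c2cc(-c3ccccc3)cc(-c3ccccc3)n2)c1` gives 11500 nM, compound 2 `Oc1cccc(-c2cc(-c3ccccc3)cc(-c3ccsc3)n2)c1` gives 10300 nM, and compound 3 `Oc1cccc(-c2cc(-c3ccccc3)cc(-c3ccco3)n2)c1` gives 9910 nM. Compound 3 thus stands level with the other two, as none of the gaps between them exceeds the scatter.

The next step leads to the unmeasured compound 4 `Oc1cccc(-c2cc(-c3ccccc3)cc(-c3ccncc3)n2)c1`, with pyridin-4-yl in place of furan-2-yl on an aromatic carbon. The exchange lies next to the ring nitrogen, at the same place that varies among the three measured compounds.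

For the measured compounds named here, three measured steps bear on it, each swapping one aromatic ring for another at this place: a 1.1-fold lower number from compound 1 to compound 2 (0.05 log units; within the scatter), a 1.2-fold lower number from compound 1 to compound 3 (0.06 log units; within the scatter) and a 1.0-fold lower number from compound 2 to compound 3 (0.02 log units; within the scatter). All three lie within the scatter. Going by the values given here, none of the measured compounds carries pyridin-4-yl, however, so the data do not show how this group behaves, and the expectation is an extrapolation with a wider range than the measured values span.

In this assay, no step beyond the scatter is expected, and the estimated step is a 1.0-fold higher number from compound 3 to compound 4 (0.00 log units; within the scatter). For compound 4 the expected value is 10000 nM, with an estimated range from 4500 nM to 22000 nM.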

Compound 4, half-maximal inhibitory concentration: 23900 nM
Compound 4: the middle estimate sits 2.4-fold (0.38 log units) below what was measured, outside the stated range (above it).
By their numbers in this assay, from the lowest: compounds 3, 2 and 1 (each within the scatter of the next); then compound 4.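

In this assay, for the compounds shown here, this position had so far given no sign of telling one aromatic ring from another, but pyridin-4-yl moves the number beyond the scatter: a 2.4-fold higher number from compound 3 to compound 4 (0.38 log units; beyond the scatter), a 2.3-fold higher number from compound 2 to compound 4 (0.37 log units; beyond the scatter) and a 2.1-fold higher number from compound 1 to compound 4 (0.32 log units; beyond the scatter). All three steps run the same way and are modest, which makes compound 4 the weakest inhibitor of the four, so the position does respond to the ring placed there, though only slightly across this set. Ring size alone does not sort the compounds, since the six-membered phenyl of compound 1 stays level with the five-membered rings of compound 2 and compound 3, and nothing available gives a reason for the shift seen with pyridin-4-yl.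

The compounds shown leave open whether the ring nitrogen itself matters or only where it sits, a question that pyridin-3-yl or pyridin-2-yl at this place would address. They also leave open how a non-aromatic group such as a piperidine or a short alkyl chain would fare here, and whether the 3-hydroxyphenyl group and the phenyl group elsewhere on the shared core respond more strongly to change.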